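The source may hold more compounds than are shown below. What is called first, only, known or untested is meant among the compounds shown, and "the series" means these compounds.

Measured in a physicochemical assay for lipophilicity, at pH 7.4; a lower number here means a more polar compound, a higher number a more lipophilic compound:
- Compound 1 `CCc1ccc(N(CC(C)C)S(=O)(=O)c2ccc3cc(OCC4CCOCC4)c(C(=O)O)cc3c2)cc1`: 1.77
- Compound 2 `CC(C)CN(c1ccc(C#N)cc1)S(=O)(=O)c1ccc2c(c1)C(=O)CC(C1CCOCC1)O2`: 3.16

Of these two, compound 2 stands higher, and the gap to compound 1 lies beyond the scatter. Compound 3 `Cc1ccc(N(CC(C)C)S(=O)(=O)c2ccc3c(c2)C(=O)CC(C2CCOCC2)O3)c(C)c1` has 2,4-dimethylphenyl in place of 4-cyanophenyl on a sulfonamide nitrogen. Among the measured compounds shown here, no measured pair shows this change, so the expectation starts from compound 2 at 3.16 and rests on the structural change alone. An upward step in this assay, beyond the scatter, is expected and estimated as a number 1.04 log units higher from compound 2 to compound 3 (beyond the scatter). For compound 3 the estimated value is 4.2, with an expected range from 3.7 to 4.8.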

Compound 3, distribution coefficient: 4.28
Estimate against measurement, compound 3: 0.08 log units below; the measured number falls inside the stated range.
By their numbers in this assay, from the lowest: compound 1; then compound 2; then compound 3.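

On a sulfonamide nitrogen, the choice of aryl group carries a large effect in this assay: 2,4-dimethylphenyl in place of 4-cyanophenyl gives a number 1.12 log units higher from compound 2 to compound 3 (beyond the scatter). Among the compounds shown here, this is the first step that changes one place only, and it lies beyond the scatter. No measurement at hand accounts for its size.

The compounds shown do not separate the loss of the nitrile from the gain of the two methyl groups. On these data alone, how a plain phenyl group, or a phenyl group carrying an amine, would read in this assay also remains open.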